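The compounds below may be only part of what the source reports. "The series", "measured", "known", "first", "only" and "open" are said of these compounds alone.

Compound 1 `Cn1ccnc1SCC(=O)Nc1ccc(-c2nc(-c3ccccc3)c(-c3ccccc3)n2C)cc1`: 32.4%
Compound 2 `CN(C)/C=C/N1CCN(CC(=O)Nc2ccc(-c3nc(-c4ccccc4)c(-c4ccccc4)n3C)cc2)CC1`: 19.4%

In a functional assay on MCF7 cells (Homo sapiens) for cytotoxicity, read by MTT assay, with a stated time of 24 h, tested at 16 ug/mL (on this read-out lower numbers stand for a weaker effect and higher numbers for a stronger effect at the one concentration tested), compound 2 stands lowest of the two numbers, set apart from compound 1 by the step of a number 13 percentage points lower from compound 1 to compound 2 (beyond the scatter). Compound 3 `Cn1c(-c2ccc(NC(=O)CN3CCN(Cc4ccc(Cl)cc4)CC3)cc2)nc(-c2ccccc2)c1-c1ccccc1` differs from compound 2 in one place: 4-chlorobenzyl in place of 2-(dimethylamino)ethenyl on an amine nitrogen in a ring. Among the compounds with values here, no measured step alters this same part of the molecule, so the single step seen, a number 13 percentage points lower from compound 1 to compound 2 (beyond the scatter), is only an indirect guide: it shows that altering the side chain on this shared core can move the number by a modest amount. Compound 3 is therefore expected to stay close to compound 2, with a step of a number 5.6 percentage points higher from compound 2 to compound 3 (within the scatter) that may not exceed the scatter. The estimate for compound 3 is 25%, ranging from 10% to 45%.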

Compound 3, a percentage reported as activity, at one concentration (the size of the read-out at that concentration, not a potency): 46.2%
Compound 3: the middle estimate sits 21.2 percentage points below what was measured; the measured number lies above the stated range.
By their numbers in this assay, from the lowest: compound 2; then compound 1; then compound 3.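

In this assay, the end group on the amine nitrogen in the ring can move the read-out by itself: 4-chlorobenzyl in place of 2-(dimethylamino)ethenyl gives a number 26.8 percentage points higher from compound 2 to compound 3 (beyond the scatter) with the rest of the molecule unchanged. The earlier step replaced the whole group on the saturated chain carbon, so it could not show this. No evidence here explains the rise. From the compounds shown here alone, it remains open whether the aromatic ring or the chlorine accounts for the change, and how a plain benzyl group or a longer phenylethyl chain would read at this nitrogen.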